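The source may hold more compounds than are shown below. What is called first, only, known or untested is meant among the compounds shown, and "the series" means these compounds.

Measured in a physicochemical assay for solubility; a lower number here means a less soluble compound, a higher number a more soluble compound:

Compound 1 `COc1cc2cc(C(=O)CC3(O)CC[N+](C)(Cc4ccccc4)CC3)sc2cc1OC`: 1250 ug/mL
Compound 2 `COc1cc2cc(CC3CC[N+](C)(Cc4ccccc4)CC3)sc2cc1OC`: 3000 ug/mL
Compound 3 `COC(=O)C[N+]1(C)CCC(CCC(=O)c2cc3cc(OC)c(OC)cc3s2)CC1`: 60000 ug/mL

Among these three, compound 3 has the highest solubility in this assay, and its lead over both compound 2 and compound 1 lies well beyond the usual scatter of repeated measurements. The next compound, compound 4 `COc1cc2cc(C(=O)CCC3CC[N+](C)(CC#N)CC3)sc2cc1OC`, keeps the core and the charged ring of compound 3 and changes one group: cyano in place of methoxycarbonyl on a saturated chain carbon bound to an amine nitrogen in a ring. No pair of measured compounds shows this change, so its effect cannot be read from the numbers shown. The expectation is a small step, if any, from compound 3 to compound 4 in this assay, which the estimate a 1.5-fold lower number from compound 3 to compound 4 (0.18 log units; within the scatter) expresses. Compound 4 is accordingly expected to give about 40000 ug/mL, with a range from 10000 ug/mL to 100000 ug/mL.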

Compound 4, solubility: 2000 ug/mL
Compound 4: middle estimate off by 20-fold (1.30 log units), on the high side, and the stated range ends above it.
By their numbers in this assay, from the lowest: compounds 1, 4 and 2 (each within the scatter of the next, the first and the last beyond it); then compound 3.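

In this assay, among these compounds, cyano in place of methoxycarbonyl on a saturated chain carbon bound to an amine nitrogen in a ring gives a 30-fold lower number from compound 3 to compound 4 (1.48 log units; beyond the scatter) in the first single-change pair here. This place on the molecule is therefore far from indifferent to the group it carries. The shared core and charged ring do not by themselves secure the high number of compound 3, and nothing shown explains the size of this drop. Still open, on these data alone, is how a carboxylic acid or an amide on this carbon would read in this assay and whether a longer chain ending in methoxycarbonyl would keep the high number.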